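This account rests on a few compounds, and the source may have more. Where it says the series, first, only, none or still open, it means among the compounds named here.

Of the compounds shown here, two from this study have been tested in a functional assay on SK-MEL-5 cells (Homo sapiens) for inhibition; a higher number here means a weaker inhibitor of growth, a lower number a stronger inhibitor of growth. For the measured compounds named here, compound 1 `CC(=O)CC/C=C(\C)CCC1=C(C)CCCC1(C)C` is the first of them. In this assay compound 1 gives no number but only a limit, > 15000 nM, which is the limit of > 15000 nM in this assay, at which 1 of the 2 values shown sits. Compound 2 `C=C1CCCC(C)(C)C1CC[C@]1(C)CC[C@@H]([C@@H](C)C(=O)O)OO1` is the second. In this assay compound 2 likewise gives only a limit, > 10000 nM, which is the limit of > 10000 nM in this assay, at which 1 of the 2 values shown sits. Compound 2 therefore stands at a limit of this assay rather than at a measured number, and its sole companion also sits at a limit, so neither can be ranked against the other. Compound 3 `C=C1CCCC(C)(C)C1CC[C@@]1(C)CC[C@H]([C@@H](C)C(=O)O)OO1` has not yet been measured. It differs from compound 2 in stereochemistry alone: the two compounds have the same atoms and bonds; at least one stereo element is drawn with a configuration in one of them and without one in the other: 2 of 4 stereo elements differ; a stereocentre at a saturated ring carbon is drawn R in compound 2 and S in compound 3; a stereocentre at a saturated ring carbon is drawn S in compound 2 and R in compound 3. Going by the values given here, no measured pair in this set shows what such a change does, so nothing measured guides the expectation. The step from compound 2 to compound 3 is expected to be a step that the limit leaves unreadable from compound 2 to compound 3, nothing beyond the usual scatter. Compound 3 is expected to give about 15000 nM, within a range from 5000 nM to 50000 nM, most likely again reported only as a limit.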

Compound 3, concentration for 50% growth inhibition: 6140 nM
Compound 3: the middle estimate sits 2.4-fold (0.39 log units) above what was measured, and the stated range covers the measured number.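

In this assay, for the compounds shown here, compound 3 is the first compound in this set to give a measured number rather than a limit, 6140 nM. Compound 2, with the same atoms and bonds, gives only a limit, > 10000 nM. Inverting the drawn configuration at two saturated ring carbons therefore comes with an at least 1.6-fold lower number from compound 2 to compound 3 (0.21 log units; that floor lies within the scatter), so the data allow a real effect of configuration at these places without proving one, and the true size of the step stays unreadable for this reason: the limit of > 10000 nM in this assay, at which 1 of the 3 values shown sits.

Still open, on these data alone, is which of the two changed ring carbons carries the step, or whether both are needed. Also open, as far as these compounds go, is how a methyl ester or an amide in place of the carboxylic acid would read in this assay.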